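This account rests on a few compounds, and the source may have more. Where it says the series, first, only, none or still open, it means among the compounds named here.

Measured compounds

Compound 1, `COc1nc(N)nc2c1c(-c1ccccc1)cn2[C@@H]1O[C@H](CO)[C@@H](O)[C@H]1O`, in a functional assay on CCRF-CEM cells (Homo sapiens), read by MTT assay, with a stated time of 72 h; on this read-out higher numbers stand for weaker inhibition and lower numbers for stronger inhibition: > 20000 nM, a limit of the assay.
Compound 2, `COc1ncnc2c1c(-c1ccccc1)cn2[C@@H]1O[C@H](CO)[C@@H](O)[C@H]1O`, in this assay: > 20000 nM, a limit of the assay.
Compound 3, `O=c1[nH]cnc2c1c(-c1ccccc1)cn2[C@@H]1O[C@H](CO)[C@@H](O)[C@H]1O`, in this assay: > 100000 nM, a limit of the assay.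

Compound 1 and compound 2 share a core and differ by amino in place of hydrogen on an aromatic carbon. The step from compound 2 to compound 1 is a step that the two limits leave unreadable from compound 2 to compound 1, since both values sit at the limit of > 20000 nM in this assay, at which 2 of the 3 values shown sit.

Compound 3 carries a core of its own; the difference between the two cores is not broken down here. Compound 3 sits at the limit of > 100000 nM in this assay, at which 1 of the 3 values shown sits.

Compound 4, `Nc1nc2c(c(-c3ccccc3)cn2[C@@H]2O[C@H](CO)[C@@H](O)[C@H]2O)c(=O)[nH]1`, is not yet measured. It differs from compound 3 by amino in place of hydrogen on an aromatic carbon. This is the same kind of change as that from compound 2 to compound 1, though the place differs: in compound 4 it is meta to a group of 1 heavy atom, whereas in compound 1 it is meta to a methoxy group (2 heavy atoms).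

For compound 4 in this assay, the step of a number no higher from compound 3 to compound 4 (the limit leaves the size open) is expected to be small, because the earlier step that the two limits leave unreadable from compound 2 to compound 1 left both compounds at a limit. Compound 4 is estimated at 100000 nM, between 30000 nM and 300000 nM, and most likely reported only as a limit.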

Compound 4, half-maximal inhibitory concentration: > 100000 nM
Compound 4: only a limit was reported; the forecaster's own chance of this, stated with the estimate: 85%; the middle value sits exactly at the limit.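

Compound 3 and compound 4 both sit at a limit of the assay, so the step between them, amino in place of hydrogen on an aromatic carbon, cannot be read in this assay: the limit of > 100000 nM in this assay, at which 2 of the 4 values shown sit.

The compounds shown leave open whether this change shifts inhibition in either pair, and how strongly any of the four compounds inhibits, as all four values are limits.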